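The source may hold more compounds than are shown below. What is called first, only, known or untested is meant among the compounds shown, and "the series" means these compounds.

Of the compounds shown here, three have been measured in a functional assay on DU-145 cells (Homo sapiens) for cytotoxicity, read by ELISA, with a stated time of 4 days (a higher number here means a weaker inhibitor, a lower number a stronger inhibitor), and their values lie close together. Compound 1 (`Clc1ccc(-c2cc(-c3ccoc3)cc(-c3ccco3)n2)s1`) gives 17200 nM, compound 2 (`Cc1ccsc1-c1cc(-c2ccc(Cl)o2)cc(-c2ccco2)n1`) gives 27300 nM and compound 3 (`Cc1ccsc1-c1cc(-c2ccc(Cl)o2)cc(-c2cccc(Cl)c2)n1`) gives 20500 nM. Compound 2 therefore stands within the scatter of both other compounds, and the three cannot be ranked on these numbers.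

Compound 4 (`Clc1ccc(-c2cc(-c3ccco3)nc(-c3ccc(Cl)s3)c2)o1`) departs from compound 2 at one place: 5-chlorothiophen-2-yl in place of 3-methylthiophen-2-yl on an aromatic carbon. In words, 5-chlorothiophen-2-yl takes the place of 3-methylthiophen-2-yl, next to the ring nitrogen.

Going by the values given here, no measured step covers this exchange. Among the compounds with values here, the only step available is a 1.3-fold lower number from compound 2 to compound 3 (0.12 log units; within the scatter), which lies within the scatter and concerns a different group, 3-chlorophenyl in place of furan-2-yl. Indirect support comes from compound 1, which already carries 5-chlorothiophen-2-yl and gives 17200 nM, within the scatter of compound 2. Within the data shown here, nothing measured so far therefore points to a large change in this assay, and no step beyond the scatter is expected in either direction. The expected change is a 1.4-fold lower number from compound 2 to compound 4 (0.14 log units; within the scatter). For compound 4 the estimated value is 20000 nM, with an expected range from 9000 nM to 42000 nM.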

Compound 4, half-maximal inhibitory concentration: 27700 nM
Beside the measured number, compound 4's estimate is 1.4-fold (0.14 log units) below it; low and high end bracket the measured number.
By their numbers in this assay, from the lowest: compounds 1, 3, 2 and 4 (each within the scatter of the next).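

In this assay, the exchange of 3-methylthiophen-2-yl for 5-chlorothiophen-2-yl, on an aromatic carbon next to the ring nitrogen, now has a measured step of its own: a 1.0-fold higher number from compound 2 to compound 4 (0.01 log units; within the scatter) is all that it produces. This place therefore takes either group, one with a methyl and the other with a chlorine on the thiophene ring and both with the same count of heavy atoms, without a difference that can be told from the scatter. The exchange of furan-3-yl for 5-chlorofuran-2-yl gives a 1.6-fold higher number from compound 1 to compound 4 (0.21 log units; within the scatter) and so also stays within the scatter, which means that neither step separates compound 4 from its neighbours.

At this place the compounds shown carry only 3-methylthiophen-2-yl or 5-chlorothiophen-2-yl, so it remains open whether an amine, a carboxylic acid or a longer alkyl chain there would move the number beyond the scatter. No other data bear on this result, and the reason for the closeness of these numbers remains unknown.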